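Enlarging the Ester Group and Its Effect on Inhibition

The source may report more compounds than this note shows. Statements on the series, on what has been measured and on what is new or still open speak of the compounds shown alone.

Compound 1, `CCOC(=O)N1CCN(C(=O)c2nc(Nc3cc(C4CC4)[nH]n3)c3cc(Cl)ccc3n2)C[C@H]1C`: 93.4%
Compound 2, `CCCCCOC(=O)N1CCN(C(=O)c2nc(Nc3cc(C4CC4)[nH]n3)c3cc(Cl)ccc3n2)C[C@H]1C`: 32.7%

In an assay for inhibition of serine/threonine-protein kinase PAK 4 (Homo sapiens), read by FRET and Z'-LYTE, with a stated time of 60 min, tested at 50 uM, in the presence of a further agent that is not named here (on this read-out lower numbers stand for a weaker effect and higher numbers for a stronger effect at the one concentration tested), compound 2 stands lowest of the two numbers, with compound 1 the nearer. Compound 3, `CC(OC(=O)C(C)C)OC(=O)N1CCN(C(=O)c2nc(Nc3cc(C4CC4)[nH]n3)c3cc(Cl)ccc3n2)C[C@H]1C`, differs from compound 2 in one place: 1-((isopropylcarbonyl)oxy)ethyl in place of pentyl on an oxygen next to a carbonyl group. Among the compounds with values here, the only measured step, a number 60.7 percentage points lower from compound 1 to compound 2 (beyond the scatter), also made the group at this oxygen larger and was large. Compound 3 carries a still larger group there, so no recovery is expected. The expected step is a number 2.7 percentage points lower from compound 2 to compound 3 (within the scatter), within the scatter. Compound 3 is therefore estimated at 30%, ranging from 5% to 65%.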

Compound 3, a percentage reported as inhibition, at one concentration (the size of the read-out at that concentration, not a potency): 71.7%
Compound 3: middle estimate off by 41.7 percentage points, on the low side, outside the stated range (above it).
By their numbers in this assay, from the lowest: compound 2; then compound 3; then compound 1.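

In this assay, the size of the group on this oxygen does not alone set the result: 1-((isopropylcarbonyl)oxy)ethyl has more heavy atoms than pentyl, yet a number 39 percentage points higher from compound 2 to compound 3 (beyond the scatter) follows from the swap. The added (isopropylcarbonyl)oxy still leaves a number 21.7 percentage points lower from compound 1 to compound 3 (beyond the scatter) as a smaller loss than the one seen with pentyl. Nothing measured here gives a reason for this difference.

The compounds shown leave open whether the oxygens and carbonyl of the new group or its branching matter more. A 2-methoxyethyl group or a butyl chain at this oxygen could help separate these.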